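Swapping one small ring for another on a sulfonyl-linked chain

The source may report more compounds than this note shows. Statements on the series, on what has been measured and on what is new or still open speak of the compounds shown alone.

Three compounds share a core and differ in the small ring attached to the saturated chain carbon bound to a sulfonyl sulfur, and in the group on the phenyl ring. In a functional assay, tested at 100 ug/mL (on this read-out lower numbers stand for a weaker effect and higher numbers for a stronger effect at the one concentration tested), compound 1 `O=S(=O)(CC1=NCCO1)C1=NNCC1c1ccccc1` is reported as "not active" (no number reported), compound 2 `Cc1ccc(C2CNN=C2S(=O)(=O)CC2=NCCO2)cc1` reaches 46.8%, and compound 3 `O=S(=O)(CC1=NCCS1)C1=NNCC1c1ccc(Cl)cc1` is reported as "not active" (no number reported). Compound 3 therefore stands without a number, like compound 1. Compound 4 `O=S(=O)(CC1=NCCO1)C1=NNCC1c1ccc(Cl)cc1` keeps the chlorine-bearing phenyl of compound 3, and the change is a group of 5 heavy atoms (3 carbon, 1 nitrogen, 1 oxygen; one five-membered non-aromatic ring with 2 hetero atoms) in place of a group of 5 heavy atoms (3 carbon, 1 nitrogen, 1 sulfur; one five-membered non-aromatic ring with 2 hetero atoms), on a saturated chain carbon bound to a sulfonyl sulfur. For the measured compounds named here, no measured pair shows this exact step, so only a small shift, if any, beyond the scatter is expected. For compound 4 in this assay the estimate is 15%, within 0% to 45%.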

Compound 4, a percentage reported as activity, at one concentration (the size of the read-out at that concentration, not a potency): "not active" (no number reported)
No number was reported for compound 4, and the estimate cannot be compared.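

Compound 3 and compound 4 are both reported without a number, so no step can be read between them, and no supporting data bear on this result. On these data alone, whether exchanging the sulfur-containing ring for the oxygen-containing ring changes activity at all remains open.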